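This account rests on a few compounds, and the source may have more. Where it says the series, first, only, none or still open, it means among the compounds named here.

Measured so far in a functional assay on PC-3 cells (Homo sapiens) for cytotoxicity, read by sulforhodamine B assay; on this read-out lower numbers stand for stronger inhibition of growth and higher numbers for weaker inhibition of growth:
compound 1 `COc1cccc(OC)c1OCCNCCOc1ccccc1OCc1ccccc1C` gives 11500 nM
compound 2 `COc1cccc(OC)c1OCCNCCOc1ccccc1OCc1ccc(C)cc1` gives 7800 nM
compound 3 `COc1cccc(OC)c1OCCNCCOc1ccccc1OCc1ccc([N+](=O)[O-])cc1` gives 12000 nM

Compound 1 stands second highest of the three numbers, with compound 3 nearest and compound 2 furthest, and both of those gaps lie within the scatter. Compound 4 `CCOc1ccc(COc2ccccc2OCCNCCOc2c(OC)cccc2OC)cc1` is still to be measured. Its difference from compound 1: 4-ethoxyphenyl in place of 2-methylphenyl on a saturated chain carbon bound to an oxygen on an aromatic ring. The two steps that bear on this change are both exchanges of the same 2-methylphenyl at the same place: a 1.5-fold lower number from compound 1 to compound 2 (0.17 log units; within the scatter) and a 1.0-fold higher number from compound 1 to compound 3 (0.02 log units; within the scatter). Neither reached beyond the scatter, so no clear movement is expected in this assay for a further change at that place. For compound 4 the expected step is a 1.2-fold lower number from compound 1 to compound 4 (0.08 log units; within the scatter). Compound 4 is therefore estimated at 9500 nM, with a range from 4500 nM to 20000 nM.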

Compound 4, concentration for 50% growth inhibition: 5200 nM
Compound 4: middle estimate off by 1.8-fold (0.26 log units), on the high side; measured number inside the range.
By their numbers in this assay, from the lowest: compounds 4, 2, 1 and 3 (each within the scatter of the next, the first and the last beyond it).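

For the compounds shown here, at the place on a saturated chain carbon bound to an oxygen on an aromatic ring, 4-ethoxyphenyl gives the first steps beyond the scatter in this assay, both modest: a 2.2-fold lower number from compound 1 to compound 4 (0.34 log units; beyond the scatter) and a 2.3-fold lower number from compound 3 to compound 4 (0.36 log units; beyond the scatter). The remaining new step stays within the scatter, a 1.5-fold lower number from compound 2 to compound 4 (0.18 log units; within the scatter), so compound 2 and compound 4 cannot be told apart. No supporting data on these steps are available.

Open, from the compounds shown here alone, is whether a longer chain such as butoxy, an amine or a carboxylic acid at this place would move the number further. Also open, going by these compounds, is whether the steps seen here would hold on a changed core.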